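A Trifluoromethyl Group Enters the Benzyl Ring

The source may hold more compounds than are shown below. What is called first, only, known or untested is meant among the compounds shown, and "the series" means these compounds.

Compound 1, `Cc1cc(C(=O)O)nn1Cc1cc(Br)ccc1OCc1ccccc1`, gives 15.1 nM in a functional assay on CHO-K1 cells for antagonist activity at prostaglandin E2 receptor EP1 subtype (Homo sapiens), read by FLIPR; on this read-out higher numbers stand for weaker inhibition and lower numbers for stronger inhibition.
Compound 2, `CC(=O)Nc1cc(C(=O)O)nn1Cc1cc(Br)ccc1OCc1ccccc1`, reaches only the assay limit of < 2000 nM in this assay, so its value is a limit and not a number.
Compound 3, `Cc1cc(C(=O)O)nn1Cc1cc(Br)ccc1OCc1ccc(Cl)cc1`, gives 8.71 nM in this assay.

Among the two real numbers, compound 1 carries the highest; its nearest neighbour is compound 3, and the step of a 1.7-fold lower number from compound 1 to compound 3 (0.24 log units; within the scatter) lies within the scatter, so the two are treated as equal. The third value, that of compound 2, sits at the limit described by the limit of < 2000 nM in this assay, at which 1 of the 3 values shown sits, and the step that the limit leaves unreadable from compound 1 to compound 2 cannot be sized.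

Compound 4, `Cc1cc(C(=O)O)nn1Cc1cc(Br)ccc1OCc1cccc(C(F)(F)F)c1`, differs from compound 1 by trifluoromethyl in place of hydrogen on an aromatic carbon. For the measured compounds named here, none of the measured steps touches this position on the benzyl ring. Going by the values given here, the only change made on that ring, the step from compound 1 to compound 3, put chloro in place of hydrogen and stayed within the scatter; that is the closest guide. The change on the shared core, from compound 1 to compound 2, concerns a different ring and is unreadable.

The expected step is therefore a 1.3-fold lower number from compound 1 to compound 4 (0.10 log units; within the scatter), no more than the scatter allows. Compound 4 is estimated to give 12 nM, within a range from 4 nM to 40 nM.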

Compound 4, inhibition constant: 1100 nM
The estimate for compound 4 lay 92-fold (1.96 log units) below the measured number; the measured number lies above the stated range.
By their numbers in this assay, from the lowest: compounds 3 and 1 (each within the scatter of the next); then compound 4.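

Putting trifluoromethyl in place of hydrogen on this aromatic carbon brings a 73-fold higher number from compound 1 to compound 4 (1.86 log units; beyond the scatter) in this assay, and here a higher number means much weaker inhibition. For the compounds shown here, the earlier compounds gave no sign of such a loss: the only other change on this six-membered aromatic ring, chloro in place of hydrogen, brought a 1.7-fold lower number from compound 1 to compound 3 (0.24 log units; within the scatter) and so showed no real change, which means that this ring does not accept every new group equally, although the two compounds cannot separate the effect of the group from the effect of the carbon that carries it. Nothing among the measurements shown explains why the number climbs so steeply.

The compounds shown leave open whether a fluorine, a methoxy group or an amine on this same aromatic carbon would stay close to the value of compound 1 at 15.1 nM or would also lose inhibition. They also leave open whether trifluoromethyl on another carbon of this ring would bring a loss of the same size, and so whether the group or the place matters more.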